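Compound 4: Aminophenyl for Hydroxyphenyl on the Anilino Nitrogen

A few compounds are considered here, and "the series" means these few. Any claim that something is new, unique, unknown or untested is made for them only; others in the source may bear on it.

Compound 1 `COc1ccc(Nc2nc(-c3cccc(F)c3)nc3ccc(F)cc23)cc1` in a functional assay on U-937 cells (Homo sapiens) for cytotoxicity, read by MTT assay, with a stated time of 48 h (on this read-out lower numbers stand for stronger inhibition and higher numbers for weaker inhibition), gives 41100 nM.
Compound 2 `Fc1cccc(-c2nc(Nc3ccc(Br)cc3)c3cc(F)ccc3n2)c1` in this assay reaches only the limit of the assay, > 50000 nM.
Compound 3 `Oc1ccc(Nc2nc(-c3cccc(F)c3)nc3ccc(F)cc23)cc1` in this assay likewise reaches only the limit of the assay, > 50000 nM.

Compound 3 therefore stands at the limit, with no number of its own; the same limit holds compound 2, which is the limit of > 50000 nM in this assay, at which 2 of the 3 values shown sit. Compound 4 `Nc1ccccc1Nc1nc(-c2cccc(F)c2)nc2ccc(F)cc12` differs from compound 3 in one place: 2-aminophenyl in place of 4-hydroxyphenyl on a nitrogen on an aromatic ring. For the measured compounds named here, no measured step exchanges a hydroxyphenyl for an aminophenyl on that nitrogen. The steps that do exist all alter the substituent on the phenyl carried by this nitrogen: an at least 1.2-fold higher number from compound 1 to compound 2 (0.08 log units; that floor lies within the scatter), an at least 1.2-fold higher number from compound 1 to compound 3 (0.08 log units; that floor lies within the scatter), and a step that the two limits leave unreadable from compound 2 to compound 3. None of these lowered the number, and two of the three values sit at the limit, so the series offers no measured change on this phenyl that reaches a stronger inhibition. Compound 4 is therefore expected to stay at or near the limit, with a step of a number no higher from compound 3 to compound 4 (the limit leaves the size open) that is not expected to pass beyond the scatter. The estimate for compound 4 in this assay is 50000 nM, within a range from 20000 nM to 120000 nM, with a real chance that only a limit is recorded.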

Compound 4, half-maximal inhibitory concentration: 47300 nM
For compound 4 the middle estimate is 1.1-fold (0.02 log units) above the measured one; the measured number falls inside the stated range.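

In this assay, 2-aminophenyl on the nitrogen gives a number where 4-hydroxyphenyl and 4-bromophenyl gave only a limit, but the steps from those two compounds are floors and do not give a true size: an at least 1.0-fold lower number from compound 3 to compound 4 (0.02 log units; that floor lies within the scatter) and an at least 1.0-fold lower number from compound 2 to compound 4 (0.02 log units; that floor lies within the scatter). For the compounds shown here, the one step between two actual numbers at this position is a 1.2-fold higher number from compound 1 to compound 4 (0.06 log units; within the scatter), so 2-aminophenyl and 4-methoxyphenyl cannot be told apart in this read-out. This position can therefore yield a number with either an amino or a methoxy group on the phenyl, yet no group shown gives a step beyond the scatter, and the limit still holds part of the set: the limit of > 50000 nM in this assay, at which 2 of the 4 values shown sit.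

The step to 2-aminophenyl changes both the group and where it sits on the phenyl, and the compounds shown do not separate these two changes. They also leave open whether a different group on this phenyl, such as a carboxylic acid or a dimethylamino group, would move the number beyond the scatter.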